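Allyl for 4-chlorophenyl on the imine nitrogen: cytotoxicity expectation

The compounds below may be only part of what the source reports. "The series", "measured", "known", "first", "only" and "open" are said of these compounds alone.

Compound 1, `C=C1CN/C(=N/c2ccccc2)S1`, gives > 100000 nM in this assay.
Compound 2, `COc1ccc(/C=C2\S/C(=N\c3ccc(Cl)cc3)N(C)C2=O)cc1`, gives > 100000 nM.

Of the compounds shown here, two have been tested in an ADME assay on TERT-RPE1 cells (Homo sapiens) for cytotoxicity, read by MTT assay, with a stated time of 72 h; a lower number here means a stronger inhibitor, a higher number a weaker inhibitor. For compound 1 the reported result is only a limit, > 100000 nM. For compound 2 the reported result is likewise only a limit, > 100000 nM. Where compound 2 stands on the numbers shown is therefore at the limit of > 100000 nM in this assay, at which 2 of the 2 values shown sit, and no step between measured compounds can be drawn from this pair.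

Compound 3, `C=CC/N=C1\S/C(=C\c2ccc(OC)cc2)C(=O)N1C`, has not yet been measured in this assay. It differs from compound 2 in one place: allyl in place of 4-chlorophenyl on a double-bonded nitrogen. The shared core of compound 2 and compound 3 is unchanged.

With both measured values resting at the same limit, the account can say nothing about how this assay responds to a change on the double-bonded nitrogen. The step from compound 2 to compound 3 is expected to give a number at a number no higher from compound 2 to compound 3 (the limit leaves the size open), that is, none beyond the scatter. Compound 3 is estimated at 100000 nM, within 50000 nM to 300000 nM, with a good chance that the assay again reports only a limit.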

Compound 3, half-maximal inhibitory concentration: > 100000 nM
Compound 3 was reported as a limit; the forecaster's own chance of this, stated with the estimate: 80%; the middle value sits exactly at the limit.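

In this assay compound 3 gives > 100000 nM, which is a limit and not a number. Compound 2 also rests at a limit, so no step can be read between compound 2 and compound 3: the limit of > 100000 nM in this assay, at which 3 of the 3 values shown sit. The compounds shown leave open whether allyl in place of 4-chlorophenyl on a double-bonded nitrogen changes the result in this assay at all.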